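Dibenzyl Ester in Place of the Guanidine Side Chain

This account rests on a few compounds, and the source may have more. Where it says the series, first, only, none or still open, it means among the compounds named here.

In a functional assay on the whole organism (Tail, strain ICR) with Mus musculus as the target, in the tail flick test, with a stated time of 60 min, at a dose of 25 umol/kg by the oral route (a higher number here means a stronger effect of the compound at the dose given, a lower number a weaker effect), the two measured compounds stand as follows:

Compound 1, `CC(C)[C@H](NC(=O)CN(c1nc(Cl)nc2[nH]cnc12)C1CC1)C(=O)OCc1ccccc1`: 55.5%
Compound 2, `N=C(N)NCCC[C@H](NC(=O)CN(c1nc(Cl)nc2[nH]cnc12)C1CC1)C(=O)OCc1ccccc1`: 30.6%

Compound 2 stands lowest of these two numbers; its nearest neighbour is compound 1, which stands higher by a number 24.9 percentage points lower from compound 1 to compound 2 (beyond the scatter), a step beyond the scatter. Compound 3, `O=C(CN(c1nc(Cl)nc2[nH]cnc12)C1CC1)N[C@@H](CCC(=O)OCc1ccccc1)C(=O)OCc1ccccc1`, differs from compound 2 by a group of 10 heavy atoms (8 carbon, 2 oxygen; one six-membered aromatic ring of carbon only) in place of a group of 5 heavy atoms (2 carbon, 3 nitrogen; no ring), on a saturated chain carbon, three bonds along the chain from an amide-type nitrogen and a carbonyl carbon. Within the data shown here, the only measured step that bears on this change is the one between compound 1 and compound 2, where the larger nitrogen-rich group in place of the three-carbon group brought a modest loss. Since the group entering in compound 3 again carries no nitrogen, a modest gain back toward compound 1 is expected, in the form of a number 14.4 percentage points higher from compound 2 to compound 3 (beyond the scatter). Compound 3 is therefore estimated at 45%, with a range from 20% to 70%.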

Compound 3, a percentage reported as activity, at one dose (the size of the read-out at that dose, not a potency): 53.7%
The estimate for compound 3 lay 8.7 percentage points below the measured number, within the range that was stated.
By their numbers in this assay, from the lowest: compound 2; then compounds 3 and 1 (each within the scatter of the next).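

In this assay, benzyloxycarbonyl in place of the group of 5 heavy atoms (2 carbon, 3 nitrogen), on a saturated chain carbon, three bonds along the chain from an amide-type nitrogen and a carbonyl carbon, gives a number 23.1 percentage points higher from compound 2 to compound 3 (beyond the scatter), so the earlier loss at this position does not follow from a larger group as such. With 2-(benzyloxycarbonyl)ethyl in place of isopropyl, the comparison gives a number 1.8 percentage points lower from compound 1 to compound 3 (within the scatter), so this position accepts a ring-bearing ester chain and compound 2 alone stands apart among the three. Nothing available explains why these side chains differ in this way.

The compounds shown leave open whether a carboxylic acid in place of the benzyl ester would keep this read-out. They also leave open whether a primary amine at the end of the chain would match the lower number of compound 2 or the higher numbers of compound 1 and compound 3.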